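Halogen swap on the enone series in a cellular assay

The source may report more compounds than this note shows. Statements on the series, on what has been measured and on what is new or still open speak of the compounds shown alone.

Measured so far:
compound 1, `O=C1/C(=C/c2cccc(Cl)c2)Cc2ccccc21`: 50900 nM
compound 2, `O=C1/C(=C/c2cccc(Br)c2)Cc2ccccc21`: 173000 nM
compound 3, `O=C1/C(=C/c2ccc(Cl)cc2)CCCc2ccccc21`: 33000 nM

All values come from a functional assay on MOLT-4 cells (Homo sapiens) for inhibition; a lower number here means a stronger inhibitor, a higher number a weaker inhibitor. Compound 1 and compound 2 share a core and differ by bromo in place of chloro on an aromatic carbon. Between them the read-out moves by a 3.4-fold higher number from compound 1 to compound 2 (0.53 log units; beyond the scatter). Compound 3 carries a different core; the difference between the two cores is not broken down here. In this assay compound 3 gives 33000 nM, a number lying within the scatter of compound 1, so no order between the two is claimed. Against compound 2, compound 3 shows the lower number.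

Compound 4, `O=C1/C(=C/c2ccc(Br)cc2)CCCc2ccccc21`, has not yet been measured. It differs from compound 3 by bromo in place of chloro on an aromatic carbon. This is the same kind of change as that from compound 1 to compound 2, made on the other core and at a different place: meta to a large group in the first pair, para to a large group in the second. With a single earlier example, and that one on another core and at another position, the expectation is only loosely anchored. A step of roughly the same direction as the earlier one is expected, so the value of compound 4 in this assay is estimated at 80000 nM, between 30000 nM and 220000 nM, which means an expected step of a 2.4-fold higher number from compound 3 to compound 4 (0.38 log units; beyond the scatter). This rests on compound 3 at 33000 nM and on the earlier step of a 3.4-fold higher number from compound 1 to compound 2 (0.53 log units; beyond the scatter).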

Compound 4, half-maximal inhibitory concentration: 54700 nM
The estimate for compound 4 lay 1.5-fold (0.17 log units) above the measured number; low and high end bracket the measured number.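

In this assay, bromo in place of chloro on an aromatic carbon, para to a large group, gives a 1.7-fold higher number from compound 3 to compound 4 (0.22 log units; within the scatter), so on this core the change is not resolved from repeat measurement and no order between the two compounds is claimed. Set beside the step on the core of compound 1, the new step cannot be told apart from the earlier one, so the data fit a change that carries over between the two cores, though they do not establish it: the same change on two cores in this assay, a 3.4-fold higher number (0.53 log units; beyond the scatter) from compound 1 to compound 2 and a 1.7-fold higher number (0.22 log units; within the scatter) from compound 3 to compound 4, 2.1-fold (0.31 log units) apart, within the scatter of two such steps. For the compounds shown here, this does not show that the effect of the change is independent of the core, since only two pairs are available, one of the two steps is itself within the scatter, and the pairs differ in the place of the halogen as well as in the core, so the contributions of core and place cannot be separated.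

Still open, on these data alone, is how either core responds when the halogen gives way to a fluoro, methoxy, amine or carboxylic acid group on the same aromatic carbon. Also open, as far as these compounds go, is whether a chloro and bromo pair at one shared place on both cores would give steps that agree.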